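This account rests on a few compounds, and the source may have more. Where it says the series, first, only, none or still open, it means among the compounds named here.

Measured in an ADME assay on microsomes from liver (Homo sapiens) for metabolic stability, with a stated time of 30 min, tested at 1 uM; on this read-out higher numbers stand for a more stable compound and lower numbers for a less stable compound:
compound 1 `COc1cc(C)c(S(=O)(=O)N(C)CCOCC(=O)N2CCC(C(C)(C)CN(C)C)CC2)c(C)c1` gives 36%
compound 2 `CN(Cc1ccc(C2=NCCN2)cc1)C(=O)COCCN(C)S(=O)(=O)c1ccccc1C#N` gives 87%
compound 3 `COc1cc(C)c(S(=O)(=O)N(C)CCOCC(=O)N2CCN([C@@H]3CN4CCC3CC4)CC2)c(C)c1` gives 57%

Compound 1 stands lowest of the three. Compound 3 lies above it by a margin beyond the scatter, and compound 2 lies higher still, also beyond the scatter. Within the data shown here, no pair of measured compounds differs in a single place, so the move to compound 4 `COc1cc(C)c(S(=O)(=O)N(C)CCOCC(=O)N2CCC(N3CCN(C(C)C)CC3)CC2)c(C)c1` rests on the structures alone. The change is 4-isopropylpiperazin-1-yl in place of 1-((dimethylamino)methyl)-1-methylethyl on a saturated ring carbon; the entering group is the larger by the counts given and carries one more acceptor.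

In this assay a modest upward step is expected, a number 12 percentage points higher from compound 1 to compound 4 (beyond the scatter), probably just beyond the scatter, because compound 3 on the shared core gives 57%. Compound 4 is estimated at 48%, within 28% to 68%.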

Compound 4, percent of the compound remaining: 54%
For compound 4 the middle estimate is 6 percentage points below the measured one; the measured number falls inside the stated range.
By their numbers in this assay, from the lowest: compound 1; then compounds 4 and 3 (each within the scatter of the next); then compound 2.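

In this assay, 4-isopropylpiperazin-1-yl in place of 1-((dimethylamino)methyl)-1-methylethyl on the saturated ring carbon gives a number 18 percentage points higher from compound 1 to compound 4 (beyond the scatter), the only single-place comparison shown in this series. The read-out at this position therefore responds to the group it carries, and the entering group, the larger of the two and the one with a ring, is accommodated with a higher number. No supporting data bear on the reason for this step.

Still open, from the compounds shown here alone, is whether the step follows the piperazine ring or its isopropyl group. A morpholin-4-yl group or a 4-methylpiperazin-1-yl group at the same carbon would separate the two.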